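This account rests on a few compounds, and the source may have more. Where it says the series, first, only, none or still open, it means among the compounds named here.

Compound 1, `O=C(/C=C/C(=O)N1C/C(=C\c2ccccc2)C(=O)/C(=C/c2ccccc2)C1)Nc1ccccc1`, is assessed in a functional assay on Molt4/C8 cells (Homo sapiens) for cytotoxicity (on this read-out higher numbers stand for weaker inhibition and lower numbers for stronger inhibition), where compound 1 gives 520 nM. Among the three compounds measured it stands second highest. Compound 3, `Cc1ccc(NC(=O)/C=C/C(=O)N2C/C(=C\c3ccc([N+](=O)[O-])cc3)C(=O)/C(=C/c3ccc([N+](=O)[O-])cc3)C2)cc1`, gives 700 nM in this assay, which lies within the scatter of compound 1. Compound 2, `Cc1cccc(C)c1NC(=O)/C=C/C(=O)N1C/C(=C\c2ccc([N+](=O)[O-])cc2)C(=O)/C(=C/c2ccc([N+](=O)[O-])cc2)C1`, gives 210 nM, a lower number beyond the scatter. Compound 4, `COc1ccc(NC(=O)/C=C/C(=O)N2C/C(=C\c3ccccc3)C(=O)/C(=C/c3ccccc3)C2)cc1`, differs from compound 1 by methoxy in place of hydrogen on an aromatic carbon. Within the data shown here, the only measured step that touches the anilide part of the core, a 3.3-fold higher number from compound 2 to compound 3 (0.52 log units; beyond the scatter), concerns other groups on that ring, and no step shows methoxy in place of hydrogen. Compound 4 is therefore expected to show a step of about a 1.0-fold lower number from compound 1 to compound 4 (0.02 log units; within the scatter), within the scatter. The estimate for compound 4 is 500 nM, between 200 nM and 1300 nM.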

Compound 4, half-maximal inhibitory concentration: 1100 nM
Estimate against measurement, compound 4: 2.2-fold (0.34 log units) below, and the stated range covers the measured number.
By their numbers in this assay, from the lowest: compound 2; then compounds 1, 3 and 4 (each within the scatter of the next, the first and the last beyond it).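

In this assay, going from phenylcarbamoyl to (4-methoxyphenyl)carbamoyl gives a 2.1-fold higher number from compound 1 to compound 4 (0.33 log units; beyond the scatter). Among these compounds, this is the first step that shows a single group entering an unsubstituted anilide ring, and it shows that methoxy on this aromatic carbon, para to a large group, moves the number upward on the core of compound 1. The earlier step compared only methyl patterns on compounds carrying nitro groups.

From the compounds shown here alone, whether an amine or a hydroxyl group in place of methoxy would shift the number the same way remains open. Nothing shown gives a reason for this step.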